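Lengthening the Chain and Trimming One Chlorine

A few compounds are considered here, and "the series" means these few. Any claim that something is new, unique, unknown or untested is made for them only; others in the source may bear on it.

Three compounds share one core and differ in the chain and the aryl group carried on the amide. In an assay on isolated protein (Mus musculus) for inhibition of IL15-IL15 receptor (Homo sapiens), read by resazurin assay, with stated times of 30 min and 2.5 days (on this read-out higher numbers stand for weaker inhibition and lower numbers for stronger inhibition), compound 1 `COc1ccc(NC(=O)CCCCCCCSc2nnc(Cc3nn(C)c(=O)c4ccccc34)n2C)cc1` gives 3900 nM, compound 2 `Cn1c(Cc2nn(C)c(=O)c3ccccc23)nnc1SCCCCCCCC(=O)Nc1ccc(Br)cc1Br` gives 1500 nM, and compound 3 `Cn1c(Cc2nn(C)c(=O)c3ccccc23)nnc1SCCCCCC(=O)Nc1ccc(Cl)cc1Cl` gives 4100 nM. Compound 3 thus shows the highest of the three numbers; its value and that of compound 1 lie within the scatter of each other, while compound 2 sits clearly lower. Going by the values given here, the only single-point step measured so far, a 2.6-fold lower number from compound 1 to compound 2 (0.41 log units; beyond the scatter), shows that swapping 4-methoxyphenyl for 2,4-dibromophenyl on the amide nitrogen gave a modest gain.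

Compound 4 `Cn1c(Cc2nn(C)c(=O)c3ccccc23)nnc1SCCCCCCCC(=O)Nc1ccc(Cl)cc1` is reached from compound 3 by 2-((4-chlorophenyl)carbamoyl)ethyl in place of (2,4-dichlorophenyl)carbamoyl on a saturated chain carbon, five bonds along the chain from a sulfur. This both lengthens the chain and replaces the 2,4-dichlorophenyl by a 4-chlorophenyl. Among the compounds with values here, the one measured step concerns the aryl group alone, and compounds 1 and 3, which differ in chain length and aryl together, sit within the scatter of each other. The expected step of a 1.3-fold lower number from compound 3 to compound 4 (0.11 log units; within the scatter) is therefore small, and compound 4 is estimated at 3200 nM, within 1200 nM to 8000 nM.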

Compound 4, half-maximal inhibitory concentration: 800 nM
Compound 4: middle estimate off by 4.0-fold (0.60 log units), on the high side, outside the stated range (below it).
By their numbers in this assay, from the lowest: compounds 4 and 2 (each within the scatter of the next); then compounds 1 and 3 (each within the scatter of the next).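

On the longer chain, chloro in place of methoxy on the aromatic carbon matters in its own right, giving a 4.9-fold lower number from compound 1 to compound 4 (0.69 log units; beyond the scatter) in this assay, while the swap to 4-chlorophenyl from 2,4-dibromophenyl gives a 1.9-fold lower number from compound 2 to compound 4 (0.27 log units; within the scatter), so a single chloro on the ring serves as well as two bromo groups. The full change, with the chain lengthened and one chlorine removed, gives a 5.1-fold lower number from compound 3 to compound 4 (0.71 log units; beyond the scatter), a clear step that neither part can claim alone. No measurement at hand explains these shifts.

Going by these compounds alone, no pair here changes only the chain or only the 2,4-dichlorophenyl ring on a fixed chain, so the shares of the two parts stay unknown. Going by these compounds, whether a still longer chain, or a 4-fluorophenyl or plain phenyl on the amide, would hold this level also remains open.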